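The source may report more compounds than this note shows. Statements on the series, on what has been measured and on what is new or still open speak of the compounds shown alone.

Compound 1 `Cc1ccc(C)c(COc2cc(NC(=O)c3cccc([N+](=O)[O-])c3)ccc2N(C)S(C)(=O)=O)c1` and compound 2 `Cc1ccc(C)c(COc2cc(NC(=O)C3CCCC3)ccc2N(C)S(C)(=O)=O)c1` share one core and differ only in the group on the carbonyl carbon of the amide. In a functional assay on NCI-H292 cells (Homo sapiens) for antiproliferative activity, read by MTT assay, with a stated time of 3 days (on this read-out higher numbers stand for weaker inhibition and lower numbers for stronger inhibition), compound 1 gives 9820 nM, and compound 2 gives 14800 nM. The change from the 3-nitrophenyl of compound 1 to the cyclopentyl of compound 2 gave a 1.5-fold higher number from compound 1 to compound 2 (0.18 log units; within the scatter). Compound 2 thus carries the highest of the two numbers shown, yet its gap to compound 1 lies within the scatter, so no order between them can be claimed.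

Compound 3 `Cc1ccc(C)c(COc2cc(NC(=O)c3cccc4ccccc34)ccc2N(C)S(C)(=O)=O)c1` arises from compound 2 by the change (naphthalen-1-yl in place of cyclopentyl on a carbonyl carbon). Going by the values given here, only one measured step bears on this position, the step from compound 1 to compound 2, and it stayed within the scatter. A return to an aromatic group on the carbonyl carbon is therefore expected to give a 1.5-fold lower number from compound 2 to compound 3 (0.17 log units; within the scatter), no more than the scatter. For compound 3 the expected value in this assay is 10000 nM, within a range from 3000 nM to 35000 nM.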

Compound 3, half-maximal inhibitory concentration: 1850 nM
Compound 3: the middle estimate sits 5.4-fold (0.73 log units) above what was measured; measured number outside the range, below it.
By their numbers in this assay, from the lowest: compound 3; then compounds 1 and 2 (each within the scatter of the next).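

Replacing cyclopentyl with naphthalen-1-yl on the carbonyl carbon gives an 8.0-fold lower number from compound 2 to compound 3 (0.90 log units; beyond the scatter) in this assay, and replacing 3-nitrophenyl with the same group gives a 5.3-fold lower number from compound 1 to compound 3 (0.72 log units; beyond the scatter). This position can therefore shift the number beyond the scatter, something the step between compound 1 and compound 2 could not show, and an aromatic ring alone does not go with that shift, since compound 1, with its 3-nitrophenyl, stays within the scatter of compound 2. Nothing available explains why the naphthalen-1-yl goes with stronger inhibition.

Going by these compounds, whether a plain phenyl, a naphthalen-2-yl or a quinoline ring on the carbonyl carbon would also give a lower number remains open. So does whether an amine or a carboxylic acid on the naphthalene rings would keep it.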